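The source may hold more compounds than are shown below. What is called first, only, known or untested is meant among the compounds shown, and "the series" means these compounds.

Compounds measured so far:
- Compound 1, `CCCC#Cc1cc([C@@H]2O[C@H](CO)[C@@H](O)[C@H]2O)n2ncnc(N)c12`: 200 nM
- Compound 2, `CCCCC#Cc1cc([C@@H]2O[C@H](CO)[C@@H](O)[C@H]2O)n2ncnc(N)c12`: 2900 nM

In a functional assay on HCT-116 cells (Homo sapiens) for antiproliferative activity, with a stated time of 72 h (on this read-out higher numbers stand for weaker inhibition and lower numbers for stronger inhibition), compound 2 gives the highest of the two numbers; its nearest neighbour, compound 1, lies a large distance away, as the step of a 15-fold higher number from compound 1 to compound 2 (1.16 log units; beyond the scatter) shows. That step involves a methyl in place of hydrogen on a saturated chain carbon, three bonds along the chain from a triple-bonded carbon, and it is beyond the scatter.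

Compound 3, `Nc1ncnn2c([C@@H]3O[C@H](CO)[C@@H](O)[C@H]3O)cc(C#Cc3cccs3)c12`, has not yet been measured. It differs from compound 2 in that (thiophen-2-yl in place of butyl on a triple-bonded carbon); cut one bond further out, the same difference reads hex-1-yn-1-yl to 2-(thiophen-2-yl)ethynyl. Within the data shown here, no measured step exchanges a chain for an aromatic ring at this position. Among the measured compounds shown here, the only step available, from compound 1 to compound 2, shows that a small change on the chain moves this read-out a great deal, so a step beyond the scatter in either direction is possible for compound 3, and the account that follows carries wide bounds. On balance compound 3 is expected to give 600 nM in this assay, within 100 nM to 4000 nM, an expected step of a 4.8-fold lower number from compound 2 to compound 3 (0.68 log units; beyond the scatter).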

Compound 3, half-maximal inhibitory concentration: 65500 nM
Beside the measured number, compound 3's estimate is 110-fold (2.04 log units) below it; the whole stated range lies below it.
By their numbers in this assay, from the lowest: compound 1; then compound 2; then compound 3.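

In this assay, thiophen-2-yl in place of butyl on a triple-bonded carbon gives a 23-fold higher number from compound 2 to compound 3 (1.35 log units; beyond the scatter), and thiophen-2-yl in place of propyl gives a 330-fold higher number from compound 1 to compound 3 (2.52 log units; beyond the scatter). The earlier pair showed only that this position responds to a small change in a saturated chain; the new result shows that an aromatic ring here gives the weakest inhibition of the series, beyond the scatter against both chains, although the groups differ little in heavy-atom count. Nothing available accounts for this loss.

As far as these compounds go, whether it belongs to thiophen-2-yl alone or extends to other rings on the triple-bonded carbon, such as phenyl or pyridin-2-yl, remains open. So does the response to an ethyl group, a cyclopropyl group or a chain ending in a hydroxyl group.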